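The source may report more compounds than this note shows. Statements on the series, on what has been measured and on what is new or still open speak of the compounds shown alone.

Measured so far in a functional assay on CRL2813 cells (Homo sapiens) for cytotoxicity, read by sulforhodamine B assay, with a stated time of 5 days; on this read-out higher numbers stand for weaker inhibition and lower numbers for stronger inhibition:
compound 1 `Cc1ccc(NC(=O)N[C@H]2CC[C@H](Oc3ccc(F)cc3)CC2)cc1`: > 20000 nM
compound 2 `COC(=O)c1cccc(NC(=O)N[C@H]2CC[C@H](Oc3ccc(F)cc3)CC2)c1`: 9200 nM
compound 3 `COc1ccccc1NC(=O)N[C@H]1CC[C@H](Oc2ccc(F)cc2)CC1`: > 20000 nM

Compound 3 stands at a limit of this assay, not at a number, namely (the limit of > 20000 nM in this assay, at which 2 of the 3 values shown sit). Within the data shown here, the one step that reaches it, a step that the two limits leave unreadable from compound 1 to compound 3, is unreadable, since both ends sit at that limit. Compound 2 alone gives a number, 9200 nM, and it shows weak inhibition.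

Compound 4 `CSc1cccc(NC(=O)N[C@H]2CC[C@H](Oc3ccc(F)cc3)CC2)c1` differs from compound 3 by 3-(methylsulfanyl)phenyl in place of 2-methoxyphenyl on an amide-type nitrogen. Among the measured compounds shown here, no measured step speaks directly to this change, and the only numbered value in the set is weak. Compound 4 is therefore expected to remain weak in this assay, with a step of an at least 1.3-fold lower number from compound 3 to compound 4 (0.12 log units; that floor lies within the scatter), and an estimate of 15000 nM, ranging from 5000 nM to 40000 nM.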

Compound 4, half-maximal inhibitory concentration: 11100 nM
Compound 4: the middle estimate sits 1.4-fold (0.13 log units) above what was measured; the range from low to high includes it.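

In this assay, 3-(methylsulfanyl)phenyl on the amide-type nitrogen brings the series off the limit, with an at least 1.8-fold lower number from compound 3 to compound 4 (0.25 log units; that floor lies within the scatter) and an at least 1.8-fold lower number from compound 1 to compound 4 (0.25 log units; that floor lies within the scatter), though neither floor clears the scatter. Methylsulfanyl and methoxycarbonyl on the aromatic carbon are not told apart, with a 1.2-fold higher number from compound 2 to compound 4 (0.08 log units; within the scatter). The first two steps are floors, not sizes, since each starts from a limit: the limit of > 20000 nM in this assay, at which 2 of the 4 values shown sit.

From the compounds shown here alone, whether an amine or a carboxylic acid in place of methylsulfanyl on the aromatic carbon would move the number beyond the scatter stays open.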